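Lengthening the alkyl chain on the ring carbon

A few compounds are considered here, and "the series" means these few. Any claim that something is new, unique, unknown or untested is made for them only; others in the source may bear on it.

compound 1 `CC1(c2ccccc2)CC(=O)C(C(CC(=O)c2ccc(-c3ccc(Br)cc3)cc2)c2ccccc2)=C(O)O1`: 8540 nM
compound 2 `CCC1(c2ccccc2)CC(=O)C(C(CC(=O)c2ccc(-c3ccc(Br)cc3)cc2)c2ccccc2)=C(O)O1`: 8510 nM

Both were tested in a functional assay on SK-MEL-2 cells (Homo sapiens) for inhibition, with a stated time of 72 h; on this read-out lower numbers stand for stronger inhibition and higher numbers for weaker inhibition. Compound 2 and compound 1 cannot be told apart here: a 1.0-fold lower number from compound 1 to compound 2 (0.00 log units; within the scatter). Compound 3 `CCCC1(c2ccccc2)CC(=O)C(C(CC(=O)c2ccc(-c3ccc(Br)cc3)cc2)c2ccccc2)=C(O)O1` carries the change (methyl in place of hydrogen on a saturated chain carbon, two bonds along the chain from a saturated ring carbon). For the measured compounds named here, the only step that bears on it is the same kind of change one bond closer in, from compound 1 to compound 2, which stayed within the scatter. On this evidence, no step beyond the scatter is expected; the estimated step is a 1.0-fold lower number from compound 2 to compound 3 (0.00 log units; within the scatter). Compound 3 is therefore expected at 8500 nM, with a range from 4000 nM to 18000 nM.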

Compound 3, half-maximal inhibitory concentration: > 10000 nM
Compound 3: only a limit was reported; the forecaster's own chance of this, stated with the estimate: 5%; middle value at least 1.1-fold (0.07 log units) from the limit.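

Compound 3 has no number in this assay, only a limit: the limit of > 10000 nM in this assay, at which 1 of the 3 values shown sits.

With the propyl chain, this position therefore gives only floors for its steps, an at least 1.1-fold higher number from compound 2 to compound 3 (0.07 log units; that floor lies within the scatter) and an at least 1.1-fold higher number from compound 1 to compound 3 (0.06 log units; that floor lies within the scatter), so the flat result from methyl to ethyl can be said neither to continue nor to end. On these data alone, the true size of either gap stays unknown.

Still open, as far as these compounds go, is whether a butyl chain or an aminoethyl group in place of the propyl chain would give a measurable number in this assay.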